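Lengthening the Chain on Compound 2

The source may report more compounds than this note shows. Statements on the series, on what has been measured and on what is new or still open speak of the compounds shown alone.

compound 1 `CN(C)CCCNc1c(C(=O)NCc2ccc(F)cc2)nc(Br)c2cccnc12`: > 10000 nM
compound 2 `CNc1c(C(=O)NCc2ccc(F)cc2)nc(Br)c2cccnc12`: > 20000 nM

In a functional assay on HCT-116 cells (Homo sapiens) for cytotoxicity, read by MTT assay, with a stated time of 72 h (a lower number here means a stronger inhibitor, a higher number a weaker inhibitor), compound 2 gives > 20000 nM, which is a limit and not a number. Compound 1 gives > 10000 nM, which is likewise a limit. Compound 2 therefore has no exact place on the scale. The change to compound 3 `NCCCCCCNc1c(C(=O)NCc2ccc(F)cc2)nc(Br)c2cccnc12` is 5-aminopentyl in place of hydrogen on a saturated chain carbon bound to a nitrogen on an aromatic ring. For the measured compounds named here, the one measured step at this place is a step that the two limits leave unreadable from compound 1 to compound 2, so it offers no size to carry over. Only a modest shift towards stronger inhibition is expected, and another limit is quite possible. The expected step is an at least 1.6-fold lower number from compound 2 to compound 3 (0.22 log units; that floor lies within the scatter), a loosely held estimate. For compound 3 the estimated value is 12000 nM, with an expected range from 3000 nM to 40000 nM.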

Compound 3, half-maximal inhibitory concentration: 7000 nM
Compound 3: the middle estimate sits 1.7-fold (0.23 log units) above what was measured, and the stated range covers the measured number.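

In this assay, compound 3 is the only one of the three compounds shown with an exact number, so a change at this place can bring the read-out within measurable range. With 5-aminopentyl in place of hydrogen on a saturated chain carbon bound to a nitrogen on an aromatic ring, the result is an at least 2.8-fold lower number from compound 2 to compound 3 (0.45 log units; beyond the scatter); even this floor clears the scatter. The comparison with the dimethylamino chain is less firm, since 3-aminopropyl in place of dimethylamino gives an at least 1.4-fold lower number from compound 1 to compound 3 (0.15 log units; that floor lies within the scatter), and the step from compound 1 to compound 2 cannot be read.

The compounds shown leave open whether the amine or the length of the chain accounts for the step. A shorter chain ending in an amine, a longer chain, or a chain of similar length ending in a carboxylic acid would help separate the two.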